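A few compounds are considered here, and "the series" means these few. Any claim that something is new, unique, unknown or untested is made for them only; others in the source may bear on it.

Measured in a functional assay on MCF7 cells (Homo sapiens) for inhibition, read by CCK-8 assay, with a stated time of 48 h; a higher number here means a weaker inhibitor, a lower number a stronger inhibitor:
- compound 1 `COc1cc(-c2ccnc3cc(-c4ccc(F)cc4)nn23)cc(OC)c1OC` gives 1280 nM
- compound 2 `COc1cc(-c2ccnc3cc(-c4ccc(C)cc4)nn23)cc(OC)c1OC` gives 47 nM
- compound 3 `COc1cc(-c2ccnc3cc(-c4ccc(N(C)C)cc4)nn23)cc(OC)c1OC` gives 44 nM

Compound 3 shares the low end of these numbers with compound 2 (a 1.1-fold lower number from compound 2 to compound 3 (0.03 log units; within the scatter)) and lies far from compound 1 (a 29-fold lower number from compound 1 to compound 3 (1.46 log units; beyond the scatter)). The next change puts 1-methyl-1H-pyrazol-4-yl in place of dimethylamino on an aromatic carbon, giving compound 4 `COc1cc(-c2ccnc3cc(-c4ccc(-c5cnn(C)c5)cc4)nn23)cc(OC)c1OC` (1-methyl-1H-pyrazol-4-yl in place of dimethylamino on an aromatic carbon).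

Changes at this place were large when fluoro left (a 27-fold lower number from compound 1 to compound 2 (1.44 log units; beyond the scatter)) but not between methyl and dimethylamino (a 1.1-fold lower number from compound 2 to compound 3 (0.03 log units; within the scatter)). For the measured compounds named here, no measured step brings in a ring, so the guidance is loose. In this assay no shift beyond the scatter is expected, with a slight lean towards a higher number (a 1.6-fold higher number from compound 3 to compound 4 (0.20 log units; within the scatter)). The estimate for compound 4 is 70 nM, with an expected range from 20 nM to 350 nM.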

Compound 4, half-maximal inhibitory concentration: 274 nM
For compound 4 the middle estimate is 3.9-fold (0.59 log units) below the measured one, and the stated range covers the measured number.
By their numbers in this assay, from the lowest: compounds 3 and 2 (each within the scatter of the next); then compound 4; then compound 1.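

In this assay, a ring at this place, the first among these compounds, gives a weaker result than either smaller group: a 6.2-fold higher number from compound 3 to compound 4 (0.79 log units; beyond the scatter), and a 5.8-fold higher number from compound 2 to compound 4 (0.77 log units; beyond the scatter). It still retains a gain over fluoro, a 4.7-fold lower number from compound 1 to compound 4 (0.67 log units; beyond the scatter), so a group as large as 1-methyl-1H-pyrazol-4-yl is tolerated here, though with some loss. No measurement to hand bears on why this order arises. From the compounds shown here alone, whether the loss follows the ring itself or its methyl remains open, as does how a pyrazole without the methyl, a morpholine ring or a methoxy group would compare.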